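This account rests on a few compounds, and the source may have more. Where it says the series, first, only, none or still open, it means among the compounds named here.

In a functional assay on RAW264.7 cells (Rattus norvegicus) for inhibition, with RAW264.7 (Mus musculus) as the target, read by Griess assay, with stated times of 2 h and 16 h (on this read-out lower numbers stand for stronger inhibition and higher numbers for weaker inhibition), compound 3 `COc1cc2c(cc1OC)C(=O)[C@H](O)[C@@H](c1cccc(O)c1O)O2` gives 50300 nM, the only numerical result among the three compounds measured. Compound 1 `COc1ccc2c(c1)C(=O)[C@H](O)[C@@H](c1cccc(O)c1O)O2` gives in this assay only a limit, > 100000 nM. Compound 2 `COc1cc2c(cc1OC)C(=O)[C@@H](O)[C@H](c1cccc(O)c1O)O2` likewise gives only a limit, > 100000 nM. Compound 4 `COc1ccc2c(c1)O[C@H](c1cccc(O)c1O)[C@@H](O)C2=O` differs from compound 3 by hydrogen in place of methoxy on an aromatic carbon. Going by the values given here, the nearest precedent runs the other way: an at least 1.9-fold lower number from compound 1 to compound 3 (0.29 log units; that floor lies within the scatter), so removing the methoxy again is expected to undo that gain. Among the compounds with values here, the other step, an at least 1.9-fold lower number from compound 2 to compound 3 (0.29 log units; that floor lies within the scatter), shows only that compound 3 sits close to the limit of > 100000 nM in this assay, at which 2 of the 3 values shown sit. Compound 4 is therefore expected to move back toward that limit, with a 3.0-fold higher number from compound 3 to compound 4 (0.47 log units; beyond the scatter). Compound 4 is estimated at 150000 nM, within a range of 60000 nM to 400000 nM.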

Compound 4, half-maximal inhibitory concentration: 24600 nM
The estimate for compound 4 lay 6.1-fold (0.79 log units) above the measured number; the whole stated range lies above it.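

In this assay, the methoxy ortho to a methoxy group turns out to be dispensable, and losing it gives a modest gain: a 2.0-fold lower number from compound 3 to compound 4 (0.31 log units; beyond the scatter). The other methoxy of compound 3 is replaced by hydrogen in compound 1. Compound 1 gives only a limit, > 100000 nM. Set against an at least 1.9-fold lower number from compound 1 to compound 3 (0.29 log units; that floor lies within the scatter), the new step suggests that the two methoxy groups do not count alike, a first sign that the place of the change matters, though that reading rests on a limit.

From the compounds shown here alone, whether an amine or an ethoxy group at this place would lower the number further remains open. So does whether the mirror image of compound 4 would show the same gain.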